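This account rests on a few compounds, and the source may have more. Where it says the series, first, only, none or still open, it means among the compounds named here.

In a functional assay on HCT-116 cells (Homo sapiens) for inhibition, read by MTT assay, with a stated time of 48 h (a lower number here means a stronger inhibitor, a higher number a weaker inhibitor), compound 1 `C#CC(=O)N(Cc1ccc(OC)c(O)c1)c1cc(OC)c(OC)c(OC)c1` gives 310 nM and compound 2 `C/C=C/C(=O)N(Cc1ccc(OC)c(O)c1)c1cc(OC)c(OC)c(OC)c1` gives 55 nM, the lower of the two numbers. Compound 3 `COc1ccc(CN(C(=O)C[Se]C#N)c2cc(OC)c(OC)c(OC)c2)cc1O` keeps the core of compound 2 and differs on the carbonyl carbon: a group of 4 heavy atoms (2 carbon, 1 nitrogen, 1 selenium; no ring) in place of a group of 3 heavy atoms (3 carbon; no ring), on a carbonyl carbon. For the measured compounds named here, the only measured step at this place is a 5.6-fold lower number from compound 1 to compound 2 (0.75 log units; beyond the scatter), and it shows that a change there can move the number in this assay. Going by the values given here, no compound containing selenium has been measured. The expected change is modest and toward a higher number, an estimated 2.2-fold higher number from compound 2 to compound 3 (0.34 log units; beyond the scatter). Compound 3 is estimated at 120 nM, with an expected range of 25 nM to 600 nM.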

Compound 3, half-maximal inhibitory concentration: 310 nM
Estimate against measurement, compound 3: 2.6-fold (0.41 log units) below; low and high end bracket the measured number.
By their numbers in this assay, from the lowest: compound 2; then compounds 1 and 3 (each within the scatter of the next).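

In this assay the group holding selenium and a nitrile on the carbonyl carbon gives a 5.6-fold higher number from compound 2 to compound 3 (0.75 log units; beyond the scatter) and so does not match prop-1-en-1-yl at this position. Set against ethynyl, the same group gives no change at the digits printed from compound 1 to compound 3 (within the scatter); of the three groups shown, only prop-1-en-1-yl stands apart. Nothing given here explains this result.

Open, from the compounds shown here alone, is how an ethyl group, an amine or a longer chain on the carbonyl carbon would compare with prop-1-en-1-yl. Also open, going by these compounds, is whether the selenium matters, which a version with sulfur in its place would test.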